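Bromo in place of tert-butyl on the shared core

This account rests on a few compounds, and the source may have more. Where it says the series, first, only, none or still open, it means among the compounds named here.

Compound 1 `CCc1ccc(-c2ccc(-c3ccc(C(=N)N)cc3)o2)cc1`: 3400 nM
Compound 2 `CC(C)(C)c1ccc(-c2ccc(-c3ccc(C(=N)N)cc3)o2)cc1`: 3200 nM

Among the compounds with values here, in a functional assay on MDA-MB-231 cells (Homo sapiens) for cytotoxicity, read by MTT assay, with a stated time of 96 h (a higher number here means a weaker inhibitor, a lower number a stronger inhibitor), compound 2 gives 3200 nM, within the scatter of compound 1, the only other compound measured. Compound 3 `N=C(N)c1ccc(-c2ccc(-c3ccc(Br)cc3)o2)cc1` carries bromo in place of tert-butyl on an aromatic carbon. Within the data shown here, one measured step bears on this change: a 1.1-fold lower number from compound 1 to compound 2 (0.03 log units; within the scatter), with tert-butyl in place of ethyl. Among the measured compounds shown here, no measured compound carries bromo, so this step is only a thin guide, and no shift beyond the scatter is expected. The estimated step is a 1.1-fold lower number from compound 2 to compound 3 (0.03 log units; within the scatter). Compound 3 is expected at 3000 nM, with an estimated range of 1200 nM to 7500 nM.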

Compound 3, half-maximal inhibitory concentration: 2700 nM
Beside the measured number, compound 3's estimate is 1.1-fold (0.05 log units) above it; the measured number falls inside the stated range.
By their numbers in this assay, from the lowest: compounds 3, 2 and 1 (each within the scatter of the next).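

In this assay bromo in place of tert-butyl gives a 1.2-fold lower number from compound 2 to compound 3 (0.07 log units; within the scatter) and bromo in place of ethyl gives a 1.3-fold lower number from compound 1 to compound 3 (0.10 log units; within the scatter) on the same aromatic carbon. A single bromine atom on the six-membered aromatic ring of carbon only therefore reads the same as either carbon chain, so all three groups at this position lie within the scatter. No evidence is available to account for this result. As far as these compounds go, whether an amine or a carboxylic acid at this position would move the number beyond the scatter remains open.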